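Chain Extension by One Carbon on the Para Alkyl Tail

The compounds below may be only part of what the source reports. "The series", "measured", "known", "first", "only" and "open" are said of these compounds alone.

Compound 1 `CCCCCCCc1ccc(CCC(N)(CO)CO)cc1` — 0.1 mg/kg
Compound 2 `CCCCCCCCCCCCCc1ccc(CCC(N)(CO)CO)cc1` — 0.03 mg/kg

Among the compounds with values here, in a functional assay on the whole organism with Rattus norvegicus as the target (a higher number here means that more compound is needed for the effect, a lower number that less compound is needed), compound 2 holds the lowest of the two numbers, and the one step among them, a 3.3-fold lower number from compound 1 to compound 2 (0.52 log units; beyond the scatter), came with hexyl in place of hydrogen. Compound 3 `CCCCCCCCCCCCCCc1ccc(CCC(N)(CO)CO)cc1` differs from compound 2 by methyl in place of hydrogen on a saturated chain carbon, ten or more bonds along the chain from an aromatic carbon. That single added carbon is far smaller than the earlier hexyl addition, so the expected step in this assay is none beyond the scatter, at most a slight lowering, a 1.2-fold lower number from compound 2 to compound 3 (0.08 log units; within the scatter). Compound 3 is therefore estimated at 0.025 mg/kg, with a range from 0.01 mg/kg to 0.06 mg/kg.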

Compound 3, dose for 50% inhibition: 1 mg/kg
Beside the measured number, compound 3's estimate is 40-fold (1.60 log units) below it; the measured number lies above the stated range.
By their numbers in this assay, from the lowest: compound 2; then compound 1; then compound 3.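

In this assay, methyl in place of hydrogen on a saturated chain carbon, ten or more bonds along the chain from an aromatic carbon, gave a 33-fold higher number from compound 2 to compound 3 (1.52 log units; beyond the scatter), reversing the direction of the earlier hexyl step. The longest chain also ends up behind the shortest, with a 10-fold higher number from compound 1 to compound 3 (1.00 log units; beyond the scatter), so across these compounds the number does not follow chain length in one direction, and a single added carbon can produce a large change. Nothing available accounts for this reversal.

The compounds shown leave open whether a longer chain raises the number further. They also leave open whether an ether oxygen within the chain or a terminal phenyl group would behave like compound 2 or compound 3.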